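Benzyl chlorine swap carried onto a second core

The source may report more compounds than this note shows. Statements on the series, on what has been measured and on what is new or still open speak of the compounds shown alone.

Two compounds on one core frame the change. Compound 1 `COc1ccc(C2N=C(SCc3cccc(Cl)c3)NC(C)=C2C(=O)Nc2ccc(F)cc2)cc1OC` and compound 2 `COc1ccc(C2N=C(SCc3ccc(Cl)cc3)NC(C)=C2C(=O)Nc2ccc(F)cc2)cc1OC` differ only in that (4-chlorophenyl in place of 3-chlorophenyl on a saturated chain carbon bound to a sulfur). In a functional assay on the whole organism (artery, strain albino) with Rattus norvegicus as the target, with a stated time of 600 min, at a dose of 10 mg/kg by the oral route (a higher number here means more inhibition at the dose given (going by the name of the read-out), a lower number less inhibition), compound 1 gives 17.4%, and compound 2 gives 26.7%; the step is a number 9.3 percentage points higher from compound 1 to compound 2 (within the scatter), so on this core the swap has not shown a clear effect.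

Compound 3 `CC1=C(C(=O)Nc2ccc(Br)cc2)C(c2ccc(Cl)cc2Cl)N=C(SCc2cccc(Cl)c2)N1` sits on another core; the difference between the two cores is not broken down here. In this assay compound 3 gives 15.4%, which lies within the scatter of compound 1, while its gap to compound 2 is beyond the scatter.

Compound 4 `CC1=C(C(=O)Nc2ccc(Br)cc2)C(c2ccc(Cl)cc2Cl)N=C(SCc2ccc(Cl)cc2)N1` has not yet been measured. It differs from compound 3 by 4-chlorophenyl in place of 3-chlorophenyl on a saturated chain carbon bound to a sulfur, the same change as from compound 1 to compound 2, at the same place. Among the compounds with values here, the only precedent is the single step of a number 9.3 percentage points higher from compound 1 to compound 2 (within the scatter), on a different core, so the expectation is thin. The step from compound 3 to compound 4 is expected to be a number 6.6 percentage points higher from compound 3 to compound 4 (within the scatter) in this assay, resting on a number 9.3 percentage points higher from compound 1 to compound 2 (within the scatter). Compound 4 is therefore estimated at 22%, with a range from 9% to 35%.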

Compound 4, a percentage reported as inhibition, in the whole organism at one dose (the size of the read-out at that dose, not a potency): 30.3%
Compound 4: the middle estimate sits 8.3 percentage points below what was measured; low and high end bracket the measured number.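

On the second core, 4-chlorophenyl in place of 3-chlorophenyl on a saturated chain carbon bound to a sulfur gives a number 14.9 percentage points higher from compound 3 to compound 4 (beyond the scatter) in this assay, so the swap has a clear effect there. Set beside the step on the first core, the size of the step does not measurably differ: the same change on two cores in this assay, a number 9.3 percentage points higher (within the scatter) from compound 1 to compound 2 and a number 14.9 percentage points higher (beyond the scatter) from compound 3 to compound 4, 5.6 percentage points apart, within the scatter of two such steps This fits a change that carries between these two cores, but it rests on only two pairs at one oral dose and one stated time, and it shows neither a gain in potency nor why the step arises, nor that it would hold on any further core.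

The compounds shown leave open whether chlorine itself matters, since a plain benzyl or a longer chain such as phenethyl in place of the 4-chlorobenzyl would test that. They also leave open how much the two cores contribute, as the pairs shown do not separate that difference.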